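Series notes: demethylation of the amide nitrogen from compound 1

The source may report more compounds than this note shows. Statements on the series, on what has been measured and on what is new or still open speak of the compounds shown alone.

Of the compounds shown here, three have been measured in a physicochemical assay for lipophilicity, using the shake flask method, at pH 7.4; on this read-out higher numbers stand for higher lipophilicity and lower numbers for lower lipophilicity. Compound 1 `COC(=O)N1CCN([C@H]2CC[C@H](Nc3ncnn4ccc([C@H](C)CC(=O)N(C)C)c34)CC2)CC1` gives 2.3, the highest of the three values; the gaps to compound 2 `CN(C)[C@H]1CC[C@H](Nc2ncnn3cccc23)CC1` at 0 and to compound 3 `CN(C)[C@H]1CC[C@H](Nc2ncnc3ccoc23)CC1` at -0.7 both lie beyond the scatter, compound 2 the nearer and compound 3 the further of the two.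

Compound 4 `CNC(=O)C[C@@H](C)c1ccn2ncnc(N[C@H]3CC[C@H](N4CCN(C(=O)OC)CC4)CC3)c12` is not yet measured in this assay and differs from compound 1 in one place: hydrogen in place of methyl on an amide-type nitrogen. Among the measured compounds shown here, no step between measured compounds shows this change, so the expectation rests only on the loss of one methyl group. A small downward step is expected, a number 0.40 log units lower from compound 1 to compound 4 (beyond the scatter), possibly within the scatter. Compound 4 is therefore estimated at 1.9, in the range 1.5 to 2.3.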

Compound 4, distribution coefficient: 2.2
Beside the measured number, compound 4's estimate is 0.30 log units below it, within the range that was stated.
By their numbers in this assay, from the lowest: compound 3; then compound 2; then compounds 4 and 1 (each within the scatter of the next).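

In this assay, among the compounds shown here, hydrogen in place of methyl on this amide-type nitrogen gives a number 0.10 log units lower from compound 1 to compound 4 (within the scatter) and so provides the first reading of a change at this position. On this read-out, dimethylcarbamoyl and methylcarbamoyl are not told apart in this one pair, which sets no trend for the series. Nothing at hand accounts for the size of this step.

Open, going by these compounds, is whether an unsubstituted amide or an ethyl group on this nitrogen would stay within the scatter. Also open, on these data alone, is where a carboxylic acid or an amine in place of the dimethylcarbamoyl would fall.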